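Cytotoxicity limits in a small diketopiperazine-type benzylidene series

The compounds below may be only part of what the source reports. "The series", "measured", "known", "first", "only" and "open" are said of these compounds alone.

Measured so far, cytotoxicity on human liver-derived cells:
Compound 1 `C=c1[nH]c(=O)/c(=C/c2ccc(OC)c(OC)c2)[nH]c1=O` gives > 20000 nM in a functional assay on Huh7.5.1 cells (Homo sapiens) for cytotoxicity, read by MTT assay, with a stated time of 72 h (a lower number here means that less compound is tolerated, a higher number that more compound is tolerated), a limit of the assay and not a number.
Compound 2 `C=c1[nH]c(=O)/c(=C/c2ccc(C)cc2)[nH]c1=O` gives > 20000 nM in this assay, again a limit.
Compound 3 `C=c1[nH]c(=O)/c(=C/c2c[nH]c3ccccc23)[nH]c1=O` gives > 20000 nM in this assay, also a limit.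

Compound 2 therefore stands where every measured compound stands: at the limit of > 20000 nM in this assay, at which 3 of the 3 values shown sit. No ordering among compounds 1, 2 and 3 can be read from these values, since each is only a limit.

Compound 4 `C=c1[nH]c(=O)/c(=C/c2ccc(C(=O)OC)cc2)[nH]c1=O` has not yet been measured in this assay. It differs from compound 2 by methoxycarbonyl in place of methyl on an aromatic carbon. Among the compounds with values here, with no measured step between compounds in the set and all values at the limit, no step beyond the scatter is expected here.

The step that the limit leaves unreadable from compound 2 to compound 4 is therefore expected to be flat, and compound 4 is expected at 30000 nM, with a range from 15000 nM to 60000 nM; most likely the assay will again report only a limit.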

Compound 4, half-maximal cytotoxic concentration: > 20000 nM
Compound 4: only a limit was reported; the forecaster's own chance of this, stated with the estimate: 85%; the middle value does not contradict the limit.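

Compound 4 gives only a limit, as compound 2 does, so no step can be read between these two compounds: the limit of > 20000 nM in this assay, at which 4 of the 4 values shown sit.

The compounds shown leave open how much of any of them is tolerated in this assay, and whether methoxycarbonyl and methyl differ there at all.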